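The source may report more compounds than this note shows. Statements on the series, on what has been measured and on what is new or still open speak of the compounds shown alone.

Of the compounds shown here, two built on one shared core have been measured in a functional assay, with a stated time of 20 min, tested at 2 mg/mL; a lower number here means a weaker effect, a higher number a stronger effect of the compound at the concentration tested. Compound 1 `CC(C)[C@@H]1CC[C@@H](C)C[C@@]12N(C)C(=O)[C@@H]1[C@H]3C(=O)N(c4ccccc4)C(=O)[C@H]3ON12` carries a plain phenyl on the amide-type nitrogen in a ring, and in this assay compound 1 gives 74.2%. Compound 2 `CC(C)[C@@H]1CC[C@@H](C)C[C@@]12N(C)C(=O)[C@@H]1[C@H]3C(=O)N(c4ccc(Cl)cc4)C(=O)[C@H]3ON12` differs from it only by chloro in place of hydrogen on an aromatic carbon, and in this assay compound 2 gives 48.2%. That single change produced a number 26 percentage points lower from compound 1 to compound 2 (beyond the scatter). Within the data shown here, compound 2 therefore stands as the lower of the two numbers measured so far, with compound 1 as its only point of comparison.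

Compound 3 `Cc1cccc(N2C(=O)[C@H]3[C@H](ON4[C@@H]3C(=O)N(C)[C@@]43C[C@H](C)CC[C@H]3C(C)C)C2=O)c1` is the next step from compound 2: 3-methylphenyl in place of 4-chlorophenyl on an amide-type nitrogen in a ring. Among the measured compounds shown here, only the step from compound 1 to compound 2 bears on this change, and it was a modest loss when the chloro was introduced; reversing that part of the change would be expected to recover a similar amount. What the methyl contributes is not covered by any measured pair, so the expectation is less certain. Compound 3 is estimated at 66%, within 46% to 86%, which corresponds to an expected step of a number 17.8 percentage points higher from compound 2 to compound 3 (beyond the scatter).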

Compound 3, a percentage reported as activity, at one concentration (the size of the read-out at that concentration, not a potency): 49.9%
Compound 3: the middle estimate sits 16.1 percentage points above what was measured; measured number inside the range.
By their numbers in this assay, from the lowest: compounds 2 and 3 (each within the scatter of the next); then compound 1.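

On the amide-type nitrogen in a ring, putting 3-methylphenyl in place of 4-chlorophenyl gives a number 1.7 percentage points higher from compound 2 to compound 3 (within the scatter) in this assay, so this assay does not separate these two substituted phenyl groups. The comparison with the plain phenyl shows a number 24.3 percentage points lower from compound 1 to compound 3 (beyond the scatter), and this sits alongside a number 26 percentage points lower from compound 1 to compound 2 (beyond the scatter): among these three compounds, both substituted phenyl groups give a lower number than the unsubstituted one, and no compound shown goes against this, so the loss is not confined to the chloro group. No supporting measurement is available to explain this shared loss.

Going by these compounds, compound 2 and compound 3 differ in both the substituent and its location on the phenyl ring, so the separate contributions of these two features remain open, and 4-methylphenyl or 3-chlorophenyl would help to tell them apart. On these data alone, it also remains open whether any substituent on this phenyl ring keeps the number as high as the plain phenyl does, for example an amine or a carboxylic acid, or whether a cyclohexyl group could replace the phenyl ring altogether.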